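Swapping the furan for a hydroxymethoxyphenyl tail

A few compounds are considered here, and "the series" means these few. Any claim that something is new, unique, unknown or untested is made for them only; others in the source may bear on it.

Measured compounds:
Compound 1 `COc1cccc(Oc2ccc3c(NCCCNCc4ccco4)ccnc3c2)c1`: 15500 nM
Compound 2 `CCC(CC)c1ccc2c(NCCCNCc3ccco3)ccnc2c1`: 6760 nM
Compound 3 `c1ccc(Cc2ccc3c(NCCCNCc4ccco4)ccnc3c2)cc1`: 16000 nM

Three compounds share a core and a chain ending in a furan group, differing only in the group on the aromatic ring of the core. In an ADME assay on HepG2 cells (Homo sapiens) for cytotoxicity, read by luminescence, CellTiter-Glo and ATP content, with a stated time of 72 h (a lower number here means that less compound is needed, a higher number that more compound is needed for the effect), compound 3 gives 16000 nM. Compound 3 and compound 1 cannot be told apart, since a 1.0-fold higher number from compound 1 to compound 3 (0.01 log units; within the scatter), while both need more compound than compound 2, as a 2.4-fold higher number from compound 2 to compound 3 (0.37 log units; beyond the scatter) shows.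

Compound 4 `COc1cccc(CNCCCNc2ccnc3cc(Cc4ccccc4)ccc23)c1O` keeps the benzyl group of compound 3 and alters the far end of the chain instead: 2-hydroxy-3-methoxyphenyl in place of furan-2-yl on a saturated chain carbon bound to an amine nitrogen.

Among the measured compounds shown here, none of the measured steps touches this part of the molecule; the steps between compound 1, compound 2 and compound 3 all concern the group on the core, and their sizes ranged from within the scatter to a 2.3-fold lower number from compound 1 to compound 2 (0.36 log units; beyond the scatter). There is therefore no direct guide for the change in compound 4, and the measured data give no reason to expect more than a modest shift in this assay in either direction.

Compound 4 is expected to give about 15000 nM, with a plausible range from 6000 nM to 40000 nM. This estimate amounts to a 1.1-fold lower number from compound 3 to compound 4 (0.03 log units; within the scatter), an expected step that stays within the usual scatter.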

Compound 4, half-maximal effective concentration: 5720 nM
The estimate for compound 4 lay 2.6-fold (0.42 log units) above the measured number; measured number outside the range, below it.
By their numbers in this assay, from the lowest: compounds 4 and 2 (each within the scatter of the next); then compounds 1 and 3 (each within the scatter of the next).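

In this assay, 2-hydroxy-3-methoxyphenyl in place of furan-2-yl gives a 2.8-fold lower number from compound 3 to compound 4 (0.45 log units; beyond the scatter) with the benzyl group on the core unchanged, so the far end of the chain can also shift this number beyond the usual scatter. Compound 1, compound 2 and compound 3 differ only in the group on the core and could not show this. The swap replaces a five-membered aromatic ring holding one hetero atom with a six-membered ring of carbon only that carries a hydroxy and a methoxy group, and no available evidence explains why the number moved.

This single step changes the ring, the hydroxy group and the methoxy group together, so a plain phenyl, a 2-hydroxyphenyl or a 3-methoxyphenyl group at the same place would be needed to separate their contributions. As far as these compounds go, it also remains open whether the same swap would produce a similar step with the 3-methoxyphenoxy group of compound 1 or the pentan-3-yl group of compound 2 on the core.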